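Alkyl chain extension on the exomethylene lactone core

This account rests on a few compounds, and the source may have more. Where it says the series, first, only, none or still open, it means among the compounds named here.

Three compounds carry numbers in a functional assay on HL-60 cells (Homo sapiens) for cytotoxicity, read by MTT assay, with a stated time of 48 h; on this read-out lower numbers stand for stronger inhibition and higher numbers for weaker inhibition. Compound 1 `C=C1CC(c2ccccc2)N(C)C1=O` gives 989000 nM in this assay. Compound 2 `O=C1OC(c2ccccc2)C/C1=C\c1ccccc1` reaches only the limit > 1000000 nM in this assay, so no number is known for it; this is also the point described by the limit of > 1000000 nM in this assay, at which 1 of the 3 values shown sits. Compound 3 `C=C1CC(C)OC1=O` gives 77400 nM in this assay, the lowest of the two numbers shown, and the nearest number, that of compound 1, sits beyond the scatter above it. For the measured compounds named here, no step between two measured compounds that differ in a single place is available, so no measured step can be drawn on.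

Compound 4 `C=C1CC(CCCCC)OC1=O` has not yet been measured in this assay. Its difference from compound 3 is butyl in place of hydrogen on a saturated chain carbon bound to a saturated ring carbon. From compound 3 to compound 4 the step is expected to be modest and toward lower numbers, around a 2.6-fold lower number from compound 3 to compound 4 (0.41 log units; beyond the scatter), though it may well remain within the scatter. For compound 4 the estimated value in this assay is 30000 nM, with an expected range from 8000 nM to 120000 nM.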

Compound 4, half-maximal inhibitory concentration: 99400 nM
Compound 4: middle estimate off by 3.3-fold (0.52 log units), on the low side; low and high end bracket the measured number.
By their numbers in this assay, from the lowest: compounds 3 and 4 (each within the scatter of the next); then compound 1. At a limit, above all of these: compound 2.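

In this assay, butyl in place of hydrogen on a saturated chain carbon bound to a saturated ring carbon gives a 1.3-fold higher number from compound 3 to compound 4 (0.11 log units; within the scatter), so this position accepts the butyl group without a change that can be told from the scatter. For the compounds shown here, this is the first step between compounds that differ in a single place, and the reading for this position rests on this one pair. No measured property shown here bears on why the step is this small.

From the compounds shown here alone, whether a longer chain, a phenyl ring, or a chain ending in an amine or a carboxylic acid at this position would give a step beyond the scatter remains open. Also open, going by these compounds, is whether the same butyl change would give a similar step on the core of compound 1.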